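Aryl variation on the shared core: outlook for compound 4

The source may hold more compounds than are shown below. What is called first, only, known or untested is meant among the compounds shown, and "the series" means these compounds.

Measured compounds and their values in a functional assay on SGC-7901 cells (Homo sapiens) for antiproliferative activity, read by MTT assay, with a stated time of 72 h; a lower number here means a stronger inhibitor, a higher number a weaker inhibitor:
compound 1, `COc1cc(-n2cnc3ccc(-c4cccc(F)c4)cc32)cc(OC)c1OC`: 2490 nM
compound 2, `COc1cc(-n2cnc3ccc(-c4ccc(C(F)(F)F)cc4)cc32)cc(OC)c1OC`: 890 nM
compound 3, `COc1cc(-n2cnc3ccc(-c4ccc(Cl)cc4Cl)cc32)cc(OC)c1OC`: > 10000 nM

For compound 3 the value is a limit of this assay and not a number (the limit of > 10000 nM in this assay, at which 1 of the 3 values shown sits). Compound 1 and compound 2 both give numbers, and the step between them is a 2.8-fold lower number from compound 1 to compound 2 (0.45 log units; beyond the scatter). Both steps into compound 3 run upward: an at least 4.0-fold higher number from compound 1 to compound 3 (0.60 log units; beyond the scatter) and an at least 11-fold higher number from compound 2 to compound 3 (1.05 log units; beyond the scatter). Compound 3 thus stands as the weakest of the three on the numbers shown, with only a bound on how weak.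

The unmeasured compound 4, `COc1cc(-n2cnc3ccc(-c4cccc(Cl)c4)cc32)cc(OC)c1OC`, differs from compound 3 in one place: 3-chlorophenyl in place of 2,4-dichlorophenyl on an aromatic carbon. The entering group resembles the 3-fluorophenyl that compound 1 carries on the same aromatic carbon. The step that bears most directly is an at least 4.0-fold higher number from compound 1 to compound 3 (0.60 log units; beyond the scatter), and a reversal of that step is expected here; an at least 11-fold higher number from compound 2 to compound 3 (1.05 log units; beyond the scatter) points the same way. A lowering beyond the scatter is therefore expected, of about an at least 4.0-fold lower number from compound 3 to compound 4 (0.60 log units; beyond the scatter), though the limit on compound 3 makes its true size uncertain. Compound 4 is expected to give roughly 2500 nM, within 800 nM to 8000 nM.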

Compound 4, half-maximal inhibitory concentration: 1490 nM
Estimate against measurement, compound 4: 1.7-fold (0.22 log units) above, within the range that was stated.
By their numbers in this assay, from the lowest: compounds 2, 4 and 1 (each within the scatter of the next, the first and the last beyond it). At a limit, above all of these: compound 3.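

In this assay, 3-chlorophenyl on this aromatic carbon gives a value that cannot be separated from those of the two earlier aryl groups with numerical values: a 1.7-fold lower number from compound 1 to compound 4 (0.22 log units; within the scatter), and a 1.7-fold higher number from compound 2 to compound 4 (0.22 log units; within the scatter). Chloro on the aryl ring therefore does not by itself go with the loss seen for 2,4-dichlorophenyl, since 3-chlorophenyl in place of that group gives an at least 6.7-fold lower number from compound 3 to compound 4 (0.82 log units; beyond the scatter). That step is only a bound, since the value of compound 3 is a limit of this assay and not a number: the limit of > 10000 nM in this assay, at which 1 of the 4 values shown sits.

The compounds shown do not tell whether the loss with 2,4-dichlorophenyl tracks one of its two chloro groups or needs both, a question that 2-chlorophenyl and 4-chlorophenyl at this aromatic carbon would address. Also open, as far as these compounds go, is how this position responds to aryl groups carrying something other than halogen or trifluoromethyl, such as an amine or a carboxylic acid, and whether the values for compound 1, compound 2 and compound 4 mark a floor for the series or only the range of these few groups.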